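The compounds below may be only part of what the source reports. "The series", "measured", "known", "first", "only" and "open" are said of these compounds alone.

Measured compounds:

- compound 1, `c1ccc(Cn2nnc3c(NC4CCCC4)nc(-c4ccccc4)nc32)cc1`: 11000000 nM
- compound 2, `Fc1ccccc1Cn1nnc2c(NC3CC3)nc(-c3ccccc3)nc21`: 15000000 nM

Both numbers come from an assay on isolated protein for binding affinity to adenosine receptor A1 (Bos taurus); on this read-out lower numbers stand for stronger inhibition and higher numbers for weaker inhibition. In this assay compound 1 gives 11000000 nM, and compound 2 gives 15000000 nM; the gap between them is within the usual scatter, so the two compounds stand together as very weak binders and neither can be set apart from the other.

Compound 3, `OC1CCC(Nc2nc(-c3ccccc3)nc3c2nnn3Cc2ccccc2)CC1`, has not yet been measured in this assay. It keeps the shared core of compound 1 and changes one group: 4-hydroxycyclohexyl in place of cyclopentyl on a nitrogen on an aromatic ring. Within the data shown here, no step between measured compounds of this kind is available, so there is nothing to lean on but the two values themselves, both of which sit far out at the weak end.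

Compound 3 is expected to remain a very weak binder, with a step of a 1.1-fold lower number from compound 1 to compound 3 (0.04 log units; within the scatter) that is not expected to go beyond the scatter in either direction. The estimate for compound 3 in this assay is 10000000 nM, with a range from 2000000 nM to 50000000 nM.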

Compound 3, inhibition constant: 2700000 nM
Compound 3: the middle estimate sits 3.7-fold (0.57 log units) above what was measured, and the stated range covers the measured number.
By their numbers in this assay, from the lowest: compound 3; then compounds 1 and 2 (each within the scatter of the next).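

In this assay, putting 4-hydroxycyclohexyl in place of cyclopentyl on the nitrogen gives a 4.1-fold lower number from compound 1 to compound 3 (0.61 log units; beyond the scatter) and so shows that the group at this position can move the number beyond the scatter, something the two earlier compounds could not show, as they differ in more than one place and their values lie within the scatter of each other. The step is modest, however: compound 3 gives 2700000 nM and remains a very weak binder, so this change improves the number without turning the compound into a strong binder. No measurement shown here gives a reason for the step.

The change swaps a five-membered ring for a six-membered one and adds a hydroxyl at the same time, so the compounds shown leave open which of the two accounts for the lower number, a question that plain cyclohexyl on the same nitrogen would address. They also leave open what an amine or a carboxylic acid in place of the hydroxyl would do, and whether any group at this position can bring binding into a much stronger range.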